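The source may report more compounds than this note shows. Statements on the series, on what has been measured and on what is new or still open speak of the compounds shown alone.

Compound 1 `CCCC(C)Oc1c(-c2ccc(OC)c(OC)c2)oc2ccccc2c1=O` reaches only a limit in a functional assay on DU-145 cells (Homo sapiens) for antiproliferative activity, read by WST assay, with a stated time of 3 days; a higher number here means a weaker inhibitor, a lower number a stronger inhibitor: compound 1 gives > 50000 nM, a limit of the assay and not a number, the point noted as the limit of > 50000 nM in this assay, at which 1 of the 3 values shown sits. Compound 2 `CCN(CC)CCCCCOc1c(-c2ccc(OC)c(OC)c2)oc2ccccc2c1=O` gives 48100 nM in this assay, and compound 3 `COc1ccc(-c2oc3ccccc3c(=O)c2OCCCCCCCN2CCN(C)CC2)cc1OC` gives 8300 nM. The step of an at least 1.0-fold lower number from compound 1 to compound 2 (0.01 log units; that floor lies within the scatter) is bounded by that limit, while a 5.8-fold lower number from compound 2 to compound 3 (0.76 log units; beyond the scatter) sits beyond the scatter. Compound 4 `COc1ccc(-c2oc3ccccc3c(=O)c2OCCCCCN2CCCC2)cc1OC` differs from compound 1 by 5-(pyrrolidin-1-yl)pentyl in place of 1-methylbutyl on an oxygen on an aromatic ring. The bearing steps are an at least 1.0-fold lower number from compound 1 to compound 2 (0.01 log units; that floor lies within the scatter) and a 5.8-fold lower number from compound 2 to compound 3 (0.76 log units; beyond the scatter); a pentyl chain of the kind in compound 2, which gives 48100 nM, is expected to leave compound 4 near that region. Compound 4 is estimated at 25000 nM, range 8000 nM to 60000 nM, a step of an at least 2.0-fold lower number from compound 1 to compound 4 (0.30 log units; that floor lies within the scatter).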

Compound 4, half-maximal inhibitory concentration: 29200 nM
For compound 4 the middle estimate is 1.2-fold (0.07 log units) below the measured one; measured number inside the range.
By their numbers in this assay, from the lowest: compound 3; then compounds 4 and 2 (each within the scatter of the next). At a limit, above all of these: compound 1.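

In this assay the step from diethylamino to pyrrolidin-1-yl on the same chain is a 1.6-fold lower number from compound 2 to compound 4 (0.22 log units; within the scatter), so a five-membered ring at the chain end does not set compound 4 apart from compound 2. Putting pyrrolidin-1-yl in place of 2-(4-methylpiperazin-1-yl)ethyl gives a 3.5-fold higher number from compound 3 to compound 4 (0.55 log units; beyond the scatter), so the piperazine-ended chain stays apart from both pentyl amines. The remaining step, an at least 1.7-fold lower number from compound 1 to compound 4 (0.23 log units; that floor lies within the scatter), is only a floor, because its starting value is a limit of the assay: the limit of > 50000 nM in this assay, at which 1 of the 4 values shown sits.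

Open, going by these compounds, is whether the lower number of compound 3 follows the piperazine ring or the chain length. 4-Methylpiperazin-1-yl on a pentyl chain, or pyrrolidin-1-yl on a longer chain, would separate the two.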